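A few compounds are considered here, and "the series" means these few. Any claim that something is new, unique, unknown or untested is made for them only; others in the source may bear on it.

In a functional assay on Bel-7402 cells (Homo sapiens) for antiproliferative activity, read by MTT assay, with a stated time of 72 h (a higher number here means a weaker inhibitor, a lower number a stronger inhibitor), compound 2 `COc1cccc(CNCc2c(C(=O)O)n(Cc3ccc(O)cc3)c3ccccc23)c1` reaches only a limit, > 50000 nM, and not a number. Compound 3 `COc1cccc(CNCc2c(C(=O)O)n(Cc3ccc(F)cc3)c3ccccc23)c1` likewise gives only the limit > 50000 nM in this assay. The change from compound 2 to compound 3 is a step that the two limits leave unreadable from compound 2 to compound 3; its size cannot be read because of the limit of > 50000 nM in this assay, at which 2 of the 3 values shown sit. Compound 1 `COc1cccc(CNCc2c(C(=O)O)n(Cc3ccccc3)c3cc(C(C)C)ccc23)c1` gives 5900 nM in this assay. Compound 4 `COc1cccc(CNCc2c(C(=O)O)n(Cc3ccc(O)cc3)c3cc(C(C)C)ccc23)c1` differs from compound 2 in one place: isopropyl in place of hydrogen on an aromatic carbon. Among the compounds with values here, no measured step isolates this change: the one measured step, from compound 2 to compound 3, yields no size, and compound 1, which also carries an isopropyl, shows a number where compound 2 shows only a limit, though those two compounds differ in more than one place. The step from compound 2 to compound 4 is therefore expected to be an at least 3.3-fold lower number from compound 2 to compound 4 (0.52 log units; beyond the scatter), toward stronger inhibition, with wide uncertainty. Compound 4 is estimated at 15000 nM, within a range from 4000 nM to 60000 nM.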

Compound 4, half-maximal inhibitory concentration: 7080 nM
Compound 4: middle estimate off by 2.1-fold (0.33 log units), on the high side, and the stated range covers the measured number.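

In this assay, compound 2 gives only a limit, > 50000 nM, and not a number. Isopropyl in place of hydrogen on this aromatic carbon of the shared core gives an at least 7.0-fold lower number from compound 2 to compound 4 (0.84 log units; beyond the scatter), the first single change shown here whose effect has a readable lower bound, and it shows that this carbon can carry a group that moves the number toward stronger inhibition. Hydroxy in place of hydrogen gives a 1.2-fold higher number from compound 1 to compound 4 (0.08 log units; within the scatter), so with the isopropyl present, the two compounds carrying or lacking the hydroxy stand within the scatter of each other.

From the compounds shown here alone, whether a methyl, a methoxy or a longer chain on this same carbon would act as the isopropyl does stays open. The step between the hydroxy and fluoro compounds cannot be read, so what that swap does stays open as well: the limit of > 50000 nM in this assay, at which 2 of the 4 values shown sit.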